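A few compounds are considered here, and "the series" means these few. Any claim that something is new, unique, unknown or untested is made for them only; others in the source may bear on it.

Working notes on the amide series. All three measured compounds share one bicyclic diamine core acylated on the ring nitrogen; only the group on the carbonyl carbon changes. Compound 1 `CC(=O)N1CC2CC(C1)N2` carries the smallest such group, and in an assay on SH-EP1 cells for displacement of a labelled ligand from Neuronal acetylcholine receptor; alpha4/beta2 (Homo sapiens), read by scintillation counting (a higher number here means a weaker inhibitor, a lower number a stronger inhibitor), compound 1 gives 150 nM. Compound 2 `CCCC(=O)N1CC2CC(C1)N2` gives 14 nM in this assay, and compound 3 `O=C(C1CC=CC1)N1CC2CC(C1)N2` gives 51 nM. Compound 1 thus stands with the highest number of the three; its nearest neighbour is compound 3, its furthest compound 2, both differences beyond the scatter.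

Among the measured compounds shown here, only one single-point step is available: an 11-fold lower number from compound 1 to compound 2 (1.03 log units; beyond the scatter). It shows a large drop in the number when the group on the carbonyl carbon is enlarged. For the measured compounds named here, the values of compound 1 and compound 3 point the same way for a ring in that position, though no single-point step links them.

Compound 4 `O=C([C@@H]1C[C@@H]1F)N1CC2CC(C1)N2` follows: 2-fluorocyclopropyl in place of methyl on a carbonyl carbon. Carbon is again added on the carbonyl carbon, so a lower number is expected, its size lying between what compound 3 and compound 2 show. The expected step is a 3.8-fold lower number from compound 1 to compound 4 (0.57 log units; beyond the scatter). Compound 4 is therefore estimated at 40 nM, with a range from 12 nM to 130 nM.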

Compound 4, inhibition constant: 1.7 nM
Beside the measured number, compound 4's estimate is 24-fold (1.37 log units) above it; measured number below the stated range.
By their numbers in this assay, from the lowest: compound 4; then compound 2; then compound 3; then compound 1.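

In this assay the change to 2-fluorocyclopropyl gives an 88-fold lower number from compound 1 to compound 4 (1.95 log units; beyond the scatter) and, set against propyl, still gives an 8.2-fold lower number from compound 2 to compound 4 (0.92 log units; beyond the scatter) and so the propyl of compound 2 marks no limit on what this position can give. A ring on the carbonyl carbon also has no fixed standing relative to the open chain: the printed number of compound 3 (51 nM) lies above that of compound 2 (14 nM), while the number of compound 4 lies below it, so ring against chain does not by itself order these compounds. The data at hand offer nothing that explains this result.

The share of the fluorine and the share of the three-membered ring remain unseparated, and a plain cyclopropyl on the carbonyl carbon would set them apart. Also open, as far as these compounds go, is how far the result depends on the two defined stereocentres of compound 4, which the mirror-image or other stereoisomeric 2-fluorocyclopropyl amides would address, and whether a longer chain such as butyl continues the drop seen with propyl.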